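A few compounds are considered here, and "the series" means these few. Any claim that something is new, unique, unknown or untested is made for them only; others in the source may bear on it.

Three compounds have been measured in a toxicity assay on WI-38 cells (Homo sapiens) for cytotoxicity, read by MTT assay, with a stated time of 48 h; a lower number here means a stronger inhibitor, a higher number a weaker inhibitor:

Compound 1, `O=C(/C=C/c1ccc2c(c1)B(O)OC2)c1ccccc1`, gives 19100 nM.
Compound 2, `O=C(/C=C/c1ccc2c(c1)B(O)OC2)c1ccc(-c2ccccc2)cc1`, gives 18300 nM.
Compound 3, `O=C(/C=C/c1ccc2c(c1)B(O)OC2)c1ccc(F)cc1`, gives 7600 nM.

Compound 3 gives the lowest of the three numbers. Compound 2 stands nearest to it and compound 1 furthest, and both gaps lie beyond the usual scatter, though only modestly.

Compound 4, `Cc1ccc(C(=O)/C=C/c2ccc3c(c2)B(O)OC3)cc1`, has not yet been measured. It differs from compound 3 in one place: methyl in place of fluoro on an aromatic carbon. Among the measured compounds shown here, two measured steps bear on this change, since both put fluoro at this same position: a 2.5-fold lower number from compound 1 to compound 3 (0.40 log units; beyond the scatter) and a 2.4-fold lower number from compound 2 to compound 3 (0.38 log units; beyond the scatter). Placing fluoro there lowered the number modestly, while phenyl at the same place, seen in compound 2, left the number essentially where compound 1 stands. For the measured compounds named here, no measured step places methyl there. A number between that of compound 3 and that of compound 1 is therefore expected, which for compound 4 means a modest rise from compound 3 near the edge of the scatter, a 1.6-fold higher number from compound 3 to compound 4 (0.20 log units; within the scatter). The estimate for compound 4 is 12000 nM, within a range from 5000 nM to 30000 nM.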

Compound 4, half-maximal inhibitory concentration: 22200 nM
Estimate against measurement, compound 4: 1.9-fold (0.27 log units) below; low and high end bracket the measured number.
By their numbers in this assay, from the lowest: compound 3; then compounds 2, 1 and 4 (each within the scatter of the next).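

In this assay, the change from fluoro to methyl on this aromatic carbon gives a 2.9-fold higher number from compound 3 to compound 4 (0.47 log units; beyond the scatter), so the lower number of compound 3 is not shared by every small group placed here, even though fluoro and methyl each count 1 heavy atom. The other two steps read a 1.2-fold higher number from compound 1 to compound 4 (0.07 log units; within the scatter) and a 1.2-fold higher number from compound 2 to compound 4 (0.08 log units; within the scatter), so hydrogen, methyl and phenyl give values that cannot be told apart at this position, and among these four groups only fluoro stands apart. Nothing available accounts for the difference between fluoro and methyl here.

From the compounds shown here alone, whether chloro, methoxy or an amine at this same place would fall with fluoro or with methyl stays open. The compounds shown also share one core, so it remains unknown whether the same change would behave alike on another.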